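A fluorine added to a weakly antiproliferative pair

A few compounds are considered here, and "the series" means these few. Any claim that something is new, unique, unknown or untested is made for them only; others in the source may bear on it.

In a functional assay on MCF7 cells (Homo sapiens) for antiproliferative activity, read by MTT assay, with a stated time of 48 h (on this read-out lower numbers stand for stronger inhibition and higher numbers for weaker inhibition), compound 1 `COc1ccc2nc(Nc3ccnc(Nc4ccc(S(N)(=O)=O)cc4)n3)sc2c1` gives 11000 nM, and compound 2 `NS(=O)(=O)c1ccc(Nc2nccc(Nc3nc4ccccc4s3)n2)cc1` gives 15300 nM; compound 2 stands as the higher of the two measured numbers, yet the step of a 1.4-fold higher number from compound 1 to compound 2 (0.14 log units; within the scatter) lies within the scatter, so the two cannot be ordered. Compound 3 `NS(=O)(=O)c1ccc(Nc2nccc(Nc3nc4ccc(F)cc4s3)n2)cc1` differs from compound 2 by fluoro in place of hydrogen on an aromatic carbon. Going by the values given here, the only measured step, from compound 1 to compound 2, changed a substituent on an aromatic carbon and stayed within the scatter, so compound 3 is expected to show no step beyond the scatter in this assay, a 1.1-fold lower number from compound 2 to compound 3 (0.04 log units; within the scatter). Compound 3 is estimated at 14000 nM, ranging from 6000 nM to 32000 nM.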

Compound 3, half-maximal inhibitory concentration: 10900 nM
Compound 3: middle estimate off by 1.3-fold (0.11 log units), on the high side; low and high end bracket the measured number.
By their numbers in this assay, from the lowest: compounds 3, 1 and 2 (each within the scatter of the next).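

With a 1.4-fold lower number from compound 2 to compound 3 (0.15 log units; within the scatter) and a 1.0-fold lower number from compound 1 to compound 3 (0.00 log units; within the scatter) as the two new steps, this place on the six-membered aromatic ring of carbon only has now held hydrogen, methoxy and fluoro with no step beyond the scatter in this assay. Fluoro, a single heavy atom, therefore cannot be told apart here from either hydrogen or the larger methoxy group. Still open, from the compounds shown here alone, is whether an amine, a carboxylic acid or a longer chain at this place would give a step beyond the scatter. No measurement shown accounts for the three compounds sitting so close together.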